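Ester in place of acid on the benzyl arm of compound 1

The source may report more compounds than this note shows. Statements on the series, on what has been measured and on what is new or still open speak of the compounds shown alone.

Compound 1, `CC#CCn1c(N2CCC[C@@H](N)C2)cc(=O)n(Cc2cccc(C(=O)O)c2Br)c1=O`, carries a carboxylic acid on its benzyl arm; in an assay on isolated protein for inhibition of Dipeptidyl peptidase 9 (Homo sapiens), read by fluorescence, with stated times of 15 min and 20 min (a higher number here means a weaker inhibitor, a lower number a stronger inhibitor), compound 1 gives "not determined" (no result reported), so no single number places it. Compound 3, `CC#CCn1c(N2CCC[C@@H](N)C2)cc(=O)n(Cc2cccc(C(=O)O)c2F)c1=O`, likewise gives "not determined" (no result reported) in this assay. Compound 2, `CC#CCn1c(N2CCC[C@@H](N)C2)cc(=O)n(Cc2ccc(Cl)c(C(=O)O)c2)c1=O`, returns only a limit of the assay, > 100 nM. Among the compounds with values here, the only evidence on the series is therefore (the limit of > 100 nM in this assay, at which 1 of the 3 values shown sits). Compound 4, `CC#CCn1c(N2CCC[C@@H](N)C2)cc(=O)n(Cc2cccc(C(=O)OC)c2Br)c1=O`, differs from compound 1 by methyl in place of hydrogen on an oxygen next to a carbonyl group, the carboxy becoming methoxycarbonyl. Within the data shown here, with no measured step between compounds to lean on, no direction of shift in this assay can be stated beyond the scatter. For compound 4 the half-maximal inhibitory concentration in this assay is estimated at 1000 nM, expected within 100 nM to 10000 nM.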

Compound 4, half-maximal inhibitory concentration: > 100 nM
Compound 4 was reported as a limit (the forecaster's own chance of this, stated with the estimate: 55%); the middle value lies beyond the limit too.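

Within the data shown here, no step from compound 1 to compound 4 can be read in this assay, as compound 1 has no single number there. Compound 4 gives > 100 nM, a limit of the assay. The compounds shown leave open whether methoxycarbonyl in place of carboxy shifts inhibition at all.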